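A few compounds are considered here, and "the series" means these few. Any claim that something is new, unique, unknown or untested is made for them only; others in the source may bear on it.

Of the compounds shown here, three on a shared core have been measured in a functional assay on MCF7 cells (Homo sapiens) for inhibition, read by MTT assay, with a stated time of 72 h; a higher number here means a weaker inhibitor, a lower number a stronger inhibitor. Compound 3 `COc1ccc(N2CCN(C(=S)N/N=C3\C(=O)Nc4ccc(Cl)cc43)CC2)cc1` stands at the lowest of the three numbers, giving 13800 nM. Compound 1 `O=C1Nc2ccc([N+](=O)[O-])cc2/C1=N/NC(=S)N1CCN(c2ccccc2)CC1` gives 23300 nM, a value within the scatter of compound 3. Compound 2 `O=C1Nc2cccc(Br)c2/C1=N/NC(=S)N1CCN(c2ccccc2)CC1` gives 40700 nM, which lies beyond the scatter from compound 3. For the measured compounds named here, no two measured compounds differ in only one place, so no single step has been isolated. Compound 4 `O=C1Nc2ccc(Cl)cc2/C1=N/NC(=S)N1CCN(c2ccc(F)cc2F)CC1` is not yet measured; it differs from compound 3 in one place: 2,4-difluorophenyl in place of 4-methoxyphenyl on an amine nitrogen in a ring. Going by the values given here, nothing among the measured compounds shows what this exchange does, so the expected step is a 1.1-fold higher number from compound 3 to compound 4 (0.04 log units; within the scatter), kept within the scatter and without a claimed direction. Compound 4 is therefore estimated at 15000 nM, with a range from 5000 nM to 45000 nM.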

Compound 4, half-maximal inhibitory concentration: 20100 nM
Compound 4: middle estimate off by 1.3-fold (0.13 log units), on the low side; the range from low to high includes it.
By their numbers in this assay, from the lowest: compounds 3, 4, 1 and 2 (each within the scatter of the next, the first and the last beyond it).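

In this assay the exchange of 4-methoxyphenyl for 2,4-difluorophenyl on an amine nitrogen in a ring is a 1.5-fold higher number from compound 3 to compound 4 (0.16 log units; within the scatter) and stays within the scatter. For the compounds shown here, this is the first single change isolated on the shared core, and at this position it gives no difference that can be told from repeat measurement. No measured evidence bears on why the step has this size. Going by these compounds, it remains open whether a benzyl group or a pyridine ring on this nitrogen would move the number beyond the scatter. On these data alone, whether the exchange behaves alike with a bromine or nitro group on the core also stays open.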